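Cutting the selenium side group down in compound 4

The compounds below may be only part of what the source reports. "The series", "measured", "known", "first", "only" and "open" are said of these compounds alone.

Three compounds share a core and differ in the selenium-bearing side group: compound 1 (`COc1ccc(N(C)c2nc(C)nc3ccccc23)cc1OCCC[Se]C#N`), compound 2 (`COc1ccc(N(C)c2nc(C)nc3ccccc23)cc1C(=O)OCC[Se]C#N`) and compound 3 (`COc1ccc(N(C)c2nc(C)nc3ccccc23)cc1C(=O)NCC[Se]C#N`). In a functional assay on LoVo cells (Homo sapiens) for inhibition, read by MTT assay, with a stated time of 48 h (a lower number here means a stronger inhibitor, a higher number a weaker inhibitor), compound 1 gives 921 nM, compound 2 gives 2960 nM and compound 3 gives 561 nM. Compound 3 thus has the lowest number of the three, but it is not separated from compound 1: a 1.6-fold lower number from compound 1 to compound 3 (0.22 log units; within the scatter). Compound 2 stands apart from both, with a 3.2-fold higher number from compound 1 to compound 2 (0.51 log units; beyond the scatter) and a 5.3-fold lower number from compound 2 to compound 3 (0.72 log units; beyond the scatter).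

Compound 4 (`COc1ccc(N(C)c2nc(C)nc3ccccc23)cc1[Se]C`) is a far larger departure from compound 3: a group of 2 heavy atoms (1 carbon, 1 selenium; no ring) in place of a group of 8 heavy atoms (4 carbon, 2 nitrogen, 1 oxygen, 1 selenium; no ring), on an aromatic carbon. The new group sits on an aromatic carbon, ortho to a methoxy group. The measured steps only exchange one long side group for another, and the largest of them is a 5.3-fold lower number from compound 2 to compound 3 (0.72 log units; beyond the scatter). Among the compounds with values here, no measured compound lacks such a group, so these steps give only a weak guide to the size of this change, and its direction is a judgement. A lower number is expected in this assay, with wide uncertainty. The expected change is a 9.4-fold lower number from compound 3 to compound 4 (0.97 log units; beyond the scatter). For compound 4 the estimated value is 60 nM, with an expected range of 5 nM to 600 nM.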

Compound 4, half-maximal inhibitory concentration: 3 nM
The estimate for compound 4 lay 20-fold (1.30 log units) above the measured number; measured number outside the range, below it.
By their numbers in this assay, from the lowest: compound 4; then compounds 3 and 1 (each within the scatter of the next); then compound 2.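

In this assay, the position needs no long chain at all for a low number: the group of 2 heavy atoms (1 carbon, 1 selenium) on this aromatic carbon gives a step (a 190-fold lower number from compound 3 to compound 4 (2.27 log units; beyond the scatter)) far larger than the widest gap among the long side groups (a 5.3-fold lower number from compound 2 to compound 3 (0.72 log units; beyond the scatter)). The same holds against the other two long groups, whether the chain carries an ether oxygen (a 310-fold lower number from compound 1 to compound 4 (2.49 log units; beyond the scatter)) or an ester (a 990-fold lower number from compound 2 to compound 4 (2.99 log units; beyond the scatter)), so the choice of linker matters much less here than the removal of the whole chain. Compound 4 also shows that neither the nitrile nor a carbonyl is required for a low number on this core, though nothing available explains why the number falls so far.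

The compounds shown do not separate the loss of the chain from the change in how selenium is held, as compound 4 alone has selenium directly on the ring. From the compounds shown here alone, whether a sulfur atom in place of selenium, an ethyl group on selenium or a nitrile directly on selenium would keep the number this low remains open.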